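A 3,4-dimethoxyphenyl swap on an inactive compound

The source may report more compounds than this note shows. Statements on the series, on what has been measured and on what is new or still open speak of the compounds shown alone.

In a functional assay on PC-3 cells (Homo sapiens) for inhibition, read by sulforhodamine B assay, with a stated time of 48 h, tested at 50 uM (on this read-out higher numbers stand for more inhibition of growth at the one concentration tested and lower numbers for less inhibition of growth), compound 1 (`COc1cc(/C=C/C(=O)/C=C/c2cccc3ccccc23)ccc1OCc1cn(CCCOc2cc(=O)oc3ccccc23)nn1`) gives 8% while compound 2 (`COc1ccccc1/C=C/C(=O)/C=C/c1ccc(OCc2cn(CCCOc3cc(=O)oc4ccccc34)nn2)c(OC)c1`) reads "not active" (no number reported) and compound 3 (`COc1cc(/C=C/C(=O)/C=C/c2ccco2)ccc1OCc1cn(CCCCOc2cc(=O)oc3ccccc23)nn1`) reads "not active" (no number reported) in the same way. Compound 2 therefore holds no single number, and only compound 1 offers a figure. Compound 4 (`COc1ccc(/C=C/C(=O)/C=C/c2ccc(OCc3cn(CCCOc4cc(=O)oc5ccccc45)nn3)c(OC)c2)cc1OC`) follows from compound 2 by one change (3,4-dimethoxyphenyl in place of 2-methoxyphenyl on a double-bonded chain carbon bound to a double-bonded chain carbon), with 3,4-dimethoxyphenyl in place of 2-methoxyphenyl on a double-bonded chain carbon bound to a double-bonded chain carbon. For the measured compounds named here, no measured pair shows what this change does. In this assay no step beyond the scatter is expected, leaving compound 4 close to compound 1 at 8% or without a number. The expected value for compound 4 is 8% within an estimated range of 0% to 20% in this test.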

Compound 4, percent growth inhibition at one concentration: 9%
The estimate for compound 4 lay 1 percentage points below the measured number; the measured number falls inside the stated range.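

In this assay putting 3,4-dimethoxyphenyl in place of naphthalen-1-yl gives a number 1 percentage points higher from compound 1 to compound 4 (within the scatter) and so shows that these two groups read alike at this place. Compound 2 reads "not active" (no number reported) and compound 4 gives 9% in the same test, but with no number for compound 2 that step cannot be read. No evidence at hand accounts for this result. Left open is whether an amine or a carboxylic acid on the phenyl group at this place would move growth inhibition beyond the scatter.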